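Trifluoromethyl in place of ethyl on the sulfonyl sulfur

The source may report more compounds than this note shows. Statements on the series, on what has been measured and on what is new or still open speak of the compounds shown alone.

Measured so far:
Compound 1, `CC1CCN(c2nc(C(F)(F)F)ccc2CNC(=O)C(C)c2ccc(NS(C)(=O)=O)c(Cl)c2)CC1`, gives 2.3 nM in an assay on cells for antagonist activity at transient receptor potential cation channel subfamily V member 1 (Homo sapiens), read by FLIPR and calcium flux, with a stated time of 15 min; a lower number here means a stronger inhibitor, a higher number a weaker inhibitor.
Compound 2, `CC1CCN(c2nc(C(F)(F)F)ccc2CNC(=O)C(C)c2cc(F)c(NS(C)(=O)=O)c(Br)c2)CC1`, gives 0.7 nM in this assay.
Compound 3, `CCS(=O)(=O)Nc1ccc(C(C)C(=O)NCc2ccc(C(F)(F)F)nc2N2CCC(C)CC2)cc1F`, gives 4.4 nM in this assay.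

Among the three numbers, compound 3 carries the highest one. Its nearest neighbour is compound 1, whose number is lower but still within the usual scatter of repeated measurements, so the two cannot be told apart with confidence. The furthest is compound 2, whose number lies beyond the scatter below that of compound 3.

Compound 4, `CC1CCN(c2nc(C(F)(F)F)ccc2CNC(=O)C(C)c2ccc(NS(=O)(=O)C(F)(F)F)c(F)c2)CC1`, has not yet been measured. It differs from compound 3 in one place: trifluoromethyl in place of ethyl on a sulfonyl sulfur. The rest of the molecule is kept as it is.

Going by the values given here, no pair of measured compounds shows this particular change, so there is nothing measured to lean on for its size. Compounds 1 and 3, which carry different small groups on the same sulfonyl sulfur, sit within the scatter of each other. On that basis a step of no more than the scatter is expected, from compound 3 to compound 4, a 1.3-fold lower number from compound 3 to compound 4 (0.10 log units; within the scatter), with the direction open. Compound 4 is therefore estimated at 3.5 nM in this assay, with a range from 0.9 nM to 14 nM.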

Compound 4, inhibition constant: "not active" (no number reported)
No number was reported for compound 4; no gap can be computed for the estimate.
By their numbers in this assay, from the lowest: compound 2; then compounds 1 and 3 (each within the scatter of the next).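

In this assay, going by these compounds alone, compound 4 is recorded as not active, with no number reported, so no step from compound 3 to compound 4 can be read. Nothing shown here bears on this result. The compounds shown leave open how large the change from ethyl to trifluoromethyl on the sulfonyl sulfur is.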